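Swapping the Dichlorophenoxy Arm of Compound 1 for Fluorophenoxy

A few compounds are considered here, and "the series" means these few. Any claim that something is new, unique, unknown or untested is made for them only; others in the source may bear on it.

Compound 1, `Nc1cc(N)c2nc(-c3ccccc3)c(Oc3ccc(Cl)c(Cl)c3)nc2c1`, gives 14500 nM in a functional assay on PC-3 cells (Homo sapiens) for inhibition, read by sulforhodamine B assay, with a stated time of 48 h (on this read-out higher numbers stand for weaker inhibition of growth and lower numbers for stronger inhibition of growth), and is the only one of the three measured compounds to return a number. Compound 2, `CCOC(=O)[C@H](CCC(=O)O)NC(=O)c1ccc(Sc2nc3cc(N)cc(N)c3nc2-c2ccccc2)cc1`, gives < 100000 nM in this assay, which is a limit of the assay rather than a number. Compound 3, `COc1cc(CNc2nc3cc(N)cc(N)c3nc2-c2ccccc2)cc(OC)c1OC`, likewise gives < 50200 nM in this assay, again a limit. Compound 4, `Nc1cc(N)c2nc(-c3ccccc3)c(Oc3ccc(F)cc3)nc2c1`, differs from compound 1 in one place: 4-fluorophenyl in place of 3,4-dichlorophenyl on an oxygen on an aromatic ring. Among the measured compounds shown here, no step between measured compounds exists here, so the expectation rests on compound 1 alone. Replacing 3,4-dichlorophenyl with 4-fluorophenyl is expected to weaken inhibition, with a step of a 2.4-fold higher number from compound 1 to compound 4 (0.38 log units; beyond the scatter) that is expected to exceed the usual scatter. For compound 4 the estimate is 35000 nM, with a range from 10000 nM to 100000 nM.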

Compound 4, concentration for total growth inhibition: 27500 nM
For compound 4 the middle estimate is 1.3-fold (0.10 log units) above the measured one, within the range that was stated.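

Among the compounds shown here, compound 1 had stood alone as the only number, with no step to read. Putting 4-fluorophenyl in place of 3,4-dichlorophenyl on the oxygen now gives, in this assay, a 1.9-fold higher number from compound 1 to compound 4 (0.28 log units; within the scatter), so this change leaves the read-out inside the usual scatter and the two arms cannot be told apart at this position.

Still open, from the compounds shown here alone, is whether a longer alkyl chain or a nitrile-bearing phenyl on that oxygen would move the number beyond the scatter. Nothing measured here bears on why these two arms read alike.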